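Allyl replaced by (trifluoromethyl)carbonyl on the shared core

This account rests on a few compounds, and the source may have more. Where it says the series, first, only, none or still open, it means among the compounds named here.

Compound 1 (`C=CCC1=C(O)S[C@](C)(CCCCCCCC)C1=O`) gives 44.4 ug/mL
Compound 2 (`CCCCCCCC[C@@]1(C)SC(O)=C(C(C)O)C1=O`) gives 23.9 ug/mL; 21 ug/mL (2 entries)

Among the measured compounds shown here, in a functional assay on MCF7 cells (Homo sapiens) for inhibition, read by radiometric assay and XTT assay (a higher number here means a weaker inhibitor, a lower number a stronger inhibitor), compound 1 stands at 44.4 ug/mL as its only single number, with one further entry giving none. Compound 2 was measured repeatedly (the several entries of compound 2 in this assay, 23.9 ug/mL; 21 ug/mL (2 entries)). Compound 3 (`CCCCCCCC[C@@]1(C)SC(O)=C(C(=O)C(F)(F)F)C1=O`) is still unmeasured and differs from compound 1 ((trifluoromethyl)carbonyl in place of allyl on a double-bonded ring carbon) with (trifluoromethyl)carbonyl in place of allyl on a double-bonded ring carbon. No measured step sizes this change, so a shift within the scatter, in no firm direction, is expected. The estimated change (a 1.5-fold lower number from compound 1 to compound 3 (0.17 log units; within the scatter)) stays small. For compound 3 the expected value is 30 ug/mL with a range of 12 ug/mL to 70 ug/mL as the likely span.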

Compound 3, half-maximal inhibitory concentration: 18.4 ug/mL
Compound 3: the middle estimate sits 1.6-fold (0.21 log units) above what was measured; low and high end bracket the measured number.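

Placing (trifluoromethyl)carbonyl instead of allyl on the double-bonded ring carbon gives a 2.4-fold lower number from compound 1 to compound 3 (0.38 log units; beyond the scatter), the first sized step at this position in this assay. The allyl group is therefore not required here for the inhibition this assay reads, and a larger group with a carbonyl is accepted. How closely the assay repeats can be judged from a single compound: the several entries of compound 2 in this assay, 23.9 ug/mL; 21 ug/mL (2 entries)

As far as these compounds go, whether the lower number belongs to the carbonyl or to the trifluoromethyl stays open, and a plain acetyl group would separate the two. From the compounds shown here alone, how an amine, a carboxylic acid or a longer alkyl chain would read on this carbon also stays open.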